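Compound 1 to compound 4: one ring group exchanged

A few compounds are considered here, and "the series" means these few. Any claim that something is new, unique, unknown or untested is made for them only; others in the source may bear on it.

In an ADME assay on microsomes from liver (Mus musculus) for metabolic stability, read by LC-MS, using NADPH, with stated times of 15 min and 60 min, tested at 4.6 uM (on this read-out lower numbers stand for a shorter-lived compound and higher numbers for a longer-lived compound), compound 1 (`CC(C)N1CCC(c2ccc3c(c2)oc(=O)n3C(=O)NCCCCc2ccccc2)CC1`) gives 1 h and compound 3 (`CN1CCC(c2ccc3c(c2)oc(=O)n3C(=O)NCCCCc2ccc(F)cc2)CC1`) gives 0.5 h as their half-lives. Within the data shown here, these two values lie within the usual scatter of each other, and they are the only true numbers so far. Compound 2 (`O=C(NCCCCc1ccccc1)n1c2c(oc1=O)CNCC2`) gives < 0.25 h as a limit of the assay and not a number.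

Compound 4 (`CN1CCC(c2ccc3c(c2)oc(=O)n3C(=O)NCCCCc2ccccc2)CC1=O`) has not yet been measured. It carries 1-methyl-2-oxopiperidin-4-yl in place of the 1-isopropylpiperidin-4-yl of compound 1, on an aromatic carbon of the shared core (1-methyl-2-oxopiperidin-4-yl in place of 1-isopropylpiperidin-4-yl on an aromatic carbon). Among the measured compounds shown here, no two measured compounds differ in only one place, so no measured step shows how large such an exchange might be. With nothing to point either way, no change beyond the scatter is expected. The estimated step is a 1.4-fold lower number from compound 1 to compound 4 (0.15 log units; within the scatter) and it stays within that scatter. For compound 4 the estimated half-life in this assay is 0.7 h with a range from 0.3 h to 1.5 h expected.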

Compound 4, half-life: 0.583 h
For compound 4 the middle estimate is 1.2-fold (0.08 log units) above the measured one; low and high end bracket the measured number.
By their numbers in this assay, from the lowest: compounds 3, 4 and 1 (each within the scatter of the next). At a limit, below all of these: compound 2.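

In this assay, among these compounds, the first step that can be read between compounds differing in only one place is a 1.7-fold lower number from compound 1 to compound 4 (0.23 log units; within the scatter). At this place on an aromatic carbon, the read-out therefore does not separate 1-methyl-2-oxopiperidin-4-yl from 1-isopropylpiperidin-4-yl, even though the entering ring carries a carbonyl and the two groups differ in what sits on the ring nitrogen. Compound 2 alone stands at a limit of the assay, which is not a number: the limit of < 0.25 h in this assay, at which 1 of the 4 values shown sits.

This single step leaves open whether a morpholine ring, a carboxylic acid or a simple primary amine at the same place would give a half-life beyond the scatter. It also leaves open whether this exchange would give a similar step on a compound with a shorter chain on the core.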